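A few compounds are considered here, and "the series" means these few. Any claim that something is new, unique, unknown or untested is made for them only; others in the source may bear on it.

In an ADME assay on L02 cells (Homo sapiens) for inhibition, read by CCK-8 assay, with a stated time of 48 h (a lower number here means a stronger inhibitor of growth, a higher number a weaker inhibitor of growth), three compounds sharing one core have been measured. Compound 1 `Cc1ccc(CNc2nc(Nc3ccc(N4CCN(C)CC4)cn3)ncc2Cl)cc1` gives > 100000 nM, which is a limit of the assay and not a number. Compound 2 `COc1cccc(CNc2nc(Nc3ccc(N4CCN(C)CC4)cn3)ncc2Cl)c1` gives 16200 nM. Compound 3 `CCc1ccc(Nc2nc(Nc3ccc(N4CCN(C)CC4)cn3)ncc2Cl)cc1` gives 12100 nM. These last two sit level, as the measured 1.3-fold lower number from compound 2 to compound 3 (0.13 log units; within the scatter) shows. The group on the nitrogen matters in this series, since an at least 8.2-fold lower number from compound 1 to compound 3 (0.91 log units; beyond the scatter) is larger, although that step starts from a limit.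

Compound 4 `Cc1cc(C)c(Nc2nc(Nc3ccc(N4CCN(C)CC4)cn3)ncc2Cl)c(C)c1` carries 2,4,6-trimethylphenyl in place of 4-ethylphenyl on a nitrogen on an aromatic ring. Among the measured compounds shown here, no measured step makes this exact swap. The two steps ending at compound 3 change the same place, and they point in different ways: one stays within the scatter, the other does not. A small step is therefore expected, leaning towards a higher number, and the estimated change is a 1.5-fold higher number from compound 3 to compound 4 (0.17 log units; within the scatter). For compound 4 the expected value is 18000 nM, with an estimated range from 7000 nM to 60000 nM.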

Compound 4, concentration for 50% growth inhibition: 20500 nM
Compound 4: the middle estimate sits 1.1-fold (0.06 log units) below what was measured; the range from low to high includes it.
By their numbers in this assay, from the lowest: compounds 3, 2 and 4 (each within the scatter of the next). At a limit, above all of these: compound 1.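

In this assay, 2,4,6-trimethylphenyl in place of 4-ethylphenyl gives a 1.7-fold higher number from compound 3 to compound 4 (0.23 log units; within the scatter), so a ring with three methyl groups on this nitrogen reads level with a ring carrying one ethyl group. Compound 4 also sits level with the benzyl-type compound 2, at a 1.3-fold higher number from compound 2 to compound 4 (0.10 log units; within the scatter), which means that 3-methoxybenzyl, 4-ethylphenyl and 2,4,6-trimethylphenyl cannot be told apart here. The only new step beyond the scatter is an at least 4.8-fold lower number from compound 1 to compound 4 (0.68 log units; beyond the scatter), and it starts from a limit: the limit of > 100000 nM in this assay, at which 1 of the 4 values shown sits.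

The compounds shown leave open what a phenyl ring bearing a carboxylic acid or an amine would give on this nitrogen, and what an open alkyl chain with no ring would give. They also leave open why compound 1 alone, with 4-methylbenzyl, stands apart from compound 2.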